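Dichloro substitution on the piperazine aryl ring: an expectation

A few compounds are considered here, and "the series" means these few. Any claim that something is new, unique, unknown or untested is made for them only; others in the source may bear on it.

Compound 1, `CC1CC(=O)N(CC(=O)N2CCN(c3cccc(Cl)c3)CC2)C1=O`: 40.3 mg/kg
Compound 2, `CC1CC(=O)N(CC(=O)N2CCN(c3ccc(Cl)cc3)CC2)C1=O`: > 250 mg/kg
Compound 3, `CC1CC(=O)N(CC(=O)N2CCN(c3cccc(Cl)c3Cl)CC2)C1=O`: not yet measured

In a functional assay on the whole organism (strain CD1) with Mus musculus as the target (on this read-out higher numbers stand for an effect only at larger amounts of compound and lower numbers for an effect already at smaller amounts), compound 1 gives 40.3 mg/kg. For compound 2 the same read-out reaches only the limit of the assay, > 250 mg/kg, so no number is known for it (the limit of > 250 mg/kg in this assay, at which 1 of the 2 values shown sits). The one measured step, an at least 6.2-fold higher number from compound 1 to compound 2 (0.79 log units; beyond the scatter), thus moves from a number to a limit, and compound 2 stands at the weak end of what is shown.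

Compound 3 differs from compound 2 in that (2,3-dichlorophenyl in place of 4-chlorophenyl on an amine nitrogen in a ring). This change removes the 4-chlorophenyl that came with the loss seen from compound 1 to compound 2 and brings in a ring that again carries chlorine at the 3-position, now together with a second chlorine. Among the measured compounds shown here, only the step from compound 1 to compound 2 bears on this, and it points to the chlorine position as decisive, so an estimated gain of an at least 3.1-fold lower number from compound 2 to compound 3 (0.49 log units; beyond the scatter) is expected, back toward the value of compound 1, though with wide uncertainty. Compound 3 is therefore estimated to give 80 mg/kg, within a range from 30 mg/kg to 250 mg/kg.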

Compound 3, dose for half-maximal effect: 74.7 mg/kg
For compound 3 the middle estimate is 1.1-fold (0.03 log units) above the measured one; the measured number falls inside the stated range.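

In this assay, 2,3-dichlorophenyl in place of 4-chlorophenyl on the amine nitrogen in the ring gives an at least 3.3-fold lower number from compound 2 to compound 3 (0.52 log units; beyond the scatter), so the weak end reached with the 4-chlorophenyl is left again once that group is gone. Compound 2 stands at a limit, so this step gives a lower bound and not a true size: the limit of > 250 mg/kg in this assay, at which 1 of the 3 values shown sits A chloro in place of hydrogen on an aromatic carbon of the ring in compound 1 gives a 1.9-fold higher number from compound 1 to compound 3 (0.27 log units; within the scatter), so compound 1 and compound 3 cannot be told apart on this read-out, and a second chlorine on that ring does not bring the loss seen with the 4-chlorophenyl.

As far as these compounds go, how a 2-chlorophenyl or a plain phenyl on the same nitrogen would read in this assay remains open, and with it whether the chlorine at the 2-position of the 2,3-dichlorophenyl contributes anything on its own. Also open, from the compounds shown here alone, are why the 4-chlorophenyl stands apart and whether a 3,4-dichlorophenyl, which keeps a chlorine at the 4-position, would stay at the weak end.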